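The source may report more compounds than this note shows. Statements on the series, on what has been measured and on what is new or still open speak of the compounds shown alone.

Measured compounds:
compound 1 `Cc1cc(=O)oc2cc(SCc3cccnc3)ccc12`, > 35200 nM (a limit)
compound 2 `CCc1cc(=O)c2ccc(Sc3cccc(Cl)n3)cc2o1`, > 31400 nM (a limit)
compound 3 `CCOc1ccc2c(=O)cc(CC)oc2c1CBr`, > 32100 nM (a limit)

In a functional assay on DU-145 cells (Homo sapiens) for antiproliferative activity, read by sulforhodamine B assay, with a stated time of 72 h (a higher number here means a weaker inhibitor of growth, a lower number a stronger inhibitor of growth), compound 1 gives only a limit, > 35200 nM. Compound 2 likewise reaches only a limit in this assay, > 31400 nM. Among the measured compounds shown here, compound 3 also stands at a limit, > 32100 nM, so no number is known for it and no step between measured compounds can be drawn. Compound 4 `CCc1cc(=O)c2ccc(OCC(C)C)c(CBr)c2o1` carries the change (isopropyl in place of methyl on a saturated chain carbon bound to an oxygen on an aromatic ring). With only limits to go on, the step that the limit leaves unreadable from compound 3 to compound 4 is expected to be none beyond the scatter, and a limit is again the likelier outcome in this assay. Compound 4 is estimated at 40000 nM, with a range from 12000 nM to 120000 nM.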

Compound 4, concentration for 50% growth inhibition: > 29400 nM
Compound 4: a limit, no number (the forecaster's own chance of this, stated with the estimate: 75%); the middle value lies beyond the limit too.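

Among the compounds shown here, compound 3 and compound 4 both stand only at limits in this assay, so no step between them can be read. The compounds shown leave open what effect, if any, isopropyl in place of methyl has on growth inhibition.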